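The source may hold more compounds than are shown below. What is called first, only, known or untested is meant among the compounds shown, and "the series" means these compounds.

Measured so far:

- Compound 1 `COc1c(Br)cc(Br)cc1C(=O)Nc1ccccc1`: in an assay for inhibition of HSP60/HSP10 (Homo sapiens), with a stated time of 60 min (a higher number here means a weaker inhibitor, a lower number a stronger inhibitor), compound 1 gives only the limit > 100000 nM.
- Compound 2 `COc1c(Br)cc(Br)cc1C(=O)Nc1cccc(Cl)c1`: in this assay compound 2 gives only the limit > 100000 nM.
- Compound 3 `O=C(Nc1cccc(Cl)c1)c1cccc(Br)c1O`: in this assay compound 3 gives only the limit > 100000 nM.

None of these three values is a real number; each one is a limit of the assay, meaning the compound did not inhibit strongly enough to be measured. Compound 2 and compound 1 share a core and differ by one change, (hydrogen in place of chloro on an aromatic carbon). The step that the two limits leave unreadable from compound 2 to compound 1 cannot be sized because both compounds sit at the limit of > 100000 nM in this assay, at which 3 of the 3 values shown sit. How the core of compound 3 differs from that of compound 2 is not broken down here.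

Compound 4 `O=C(Nc1ccccc1)c1cccc(Br)c1O` has not yet been measured. Going by the values given here, it differs from compound 3 by hydrogen in place of chloro on an aromatic carbon, which is the same kind of change as the one from compound 2 to compound 1. That earlier change gave an unreadable step between two limits, and compound 3 itself stands at a limit, so there is nothing in the measured compounds pointing toward a readable gain. Compound 4 is therefore expected to stay near the limit as well, with a step of a number no higher from compound 3 to compound 4 (the limit leaves the size open) expected in this assay. For compound 4 the estimate in this assay is 100000 nM. The expected range for compound 4 runs from 40000 nM to 300000 nM.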

Compound 4, half-maximal inhibitory concentration: > 100000 nM
Compound 4 was reported as a limit (the forecaster's own chance of this, stated with the estimate: 85%); the middle value lies on the limit itself.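

No size can be given for the change from compound 3 to compound 4, and the same holds for the earlier change from compound 2 to compound 1, because each compound gives only a limit of the assay and not a number: the limit of > 100000 nM in this assay, at which 4 of the 4 values shown sit.

The compounds shown leave open whether hydrogen in place of chloro alters inhibition at all, and what change to these structures would give a measurable value.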